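Swapping a Ring Oxygen for Sulfur in Cytotoxic Thiosemicarbazides

The source may report more compounds than this note shows. Statements on the series, on what has been measured and on what is new or still open speak of the compounds shown alone.

Three compounds sharing an amidine-thiosemicarbazide arrangement were tested for their effect on the growth of a human melanoma cell line. In a functional assay on A-375 cells (Homo sapiens) for cytotoxicity, read by MTT assay, with a stated time of 72 h, tested at 100 uM (on this read-out higher numbers stand for more inhibition of growth at the one concentration tested and lower numbers for less inhibition of growth), compound 1 `Cc1ccnc(/C(N)=N/NC(=S)N2CCOCC2)c1` gives 90.6%. Its thiomorpholine partner is compound 2 `Cc1ccnc(/C(N)=N/NC(=S)N2CCSCC2)c1`, and in this assay compound 2 gives 89.9%. Compound 3 `N/C(=N\NC(=S)N1CCSCC1)c1ccc(F)cn1` carries a different pyridine core and gives 83.2% in this assay, the lowest of the three numbers, though each of its gaps to compound 1 and to compound 2 lies within the usual scatter of this kind of measurement.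

Compound 1 arises from compound 2 by one change, (morpholin-4-yl in place of thiomorpholin-4-yl on a thiocarbonyl carbon). The step of a number 0.7 percentage points higher from compound 2 to compound 1 (within the scatter) is small and lies within the scatter, so this change left the growth inhibition essentially unchanged on that core. How the core of compound 3 differs from that of compound 2 is not broken down here.

Compound 4 `N/C(=N\NC(=S)N1CCOCC1)c1ccc(F)cn1` has not yet been measured. It arises from compound 3 by morpholin-4-yl in place of thiomorpholin-4-yl on a thiocarbonyl carbon. The place of the change is described in the same words for both pairs, so this is the same change seen between compound 2 and compound 1. Because the step of a number 0.7 percentage points higher from compound 2 to compound 1 (within the scatter) was within the scatter, the expected step of a number 0.8 percentage points higher from compound 3 to compound 4 (within the scatter) is also small. Compound 4 is therefore estimated to give 84% in this assay, with a likely range from 74% to 93%.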

Compound 4, percent growth inhibition at one concentration: 86.2%
The estimate for compound 4 lay 2.2 percentage points below the measured number; measured number inside the range.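

In this assay, among the compounds shown here, placing morpholin-4-yl where thiomorpholin-4-yl stood on the thiocarbonyl carbon gives a number 3 percentage points higher from compound 3 to compound 4 (within the scatter), so on this second core as well the swap produces no step that can be told apart from ordinary measurement noise. Set beside the earlier pair, the two results agree, and the swap reads the same on both cores: the same change on two cores in this assay, a number 0.7 percentage points higher (within the scatter) from compound 2 to compound 1 and a number 3 percentage points higher (within the scatter) from compound 3 to compound 4, 2.3 percentage points apart, within the scatter of two such steps

This shows that, for these two pairs, choosing between the two rings made no readable difference to growth inhibition at the one concentration tested, but it does not show that the rings are interchangeable on other cores, in other cells or at lower concentrations, where differences might appear.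

The compounds shown carry only these two rings on the thiocarbonyl carbon, so it remains open how a piperazine ring or an open-chain group such as dimethylamino would behave in that place. As far as these compounds go, it also remains open what a methoxy group on the pyridine core would give, and whether the ring swap would stay as small on such a core.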